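A few compounds are considered here, and "the series" means these few. Any claim that something is new, unique, unknown or untested is made for them only; others in the source may bear on it.

Measured so far in a physicochemical assay for permeability, using PAMPA; a lower number here means that the compound crosses the layer more slowly, a higher number that the compound crosses the layer faster

compound 1 `Cc1oc(-c2ccccc2Cl)nc1CN1CCC(C(=O)NCCCN2C[C@H](C)C[C@H](C)C2)CC1` 352 10^-6 cm/s
compound 2 `Cc1ccccc1-c1nc(CN2CCC(C(=O)NCCCN3[C@H](C)CCC[C@@H]3C)CC2)c(C)o1` 55.4 10^-6 cm/s

Of the two, compound 1 holds the higher number in this assay and compound 2 lies lower, by a gap beyond the scatter. Compound 3 `Cc1oc(-c2c(F)cccc2F)nc1CN1CCC(C(=O)NCCCN2C[C@H](C)C[C@H](C)C2)CC1` differs from compound 1 by 2,6-difluorophenyl in place of 2-chlorophenyl on an aromatic carbon. Within the data shown here, no step at a single place has been measured, so the size of the change remains open. A small downward step, within the scatter, is expected (a 1.5-fold lower number from compound 1 to compound 3 (0.18 log units; within the scatter)). Compound 3 is estimated at 230 10^-6 cm/s (expected range 90 10^-6 cm/s to 480 10^-6 cm/s).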

Compound 3, apparent permeability: 82.4 10^-6 cm/s
Estimate against measurement, compound 3: 2.8-fold (0.45 log units) above, outside the stated range (below it).
By their numbers in this assay, from the lowest: compounds 2 and 3 (each within the scatter of the next); then compound 1.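

In this assay, among these compounds, 2,6-difluorophenyl in place of 2-chlorophenyl gives a 4.3-fold lower number from compound 1 to compound 3 (0.63 log units; beyond the scatter) as the first step at a single place. The aromatic carbon of the five-membered ring with 1 nitrogen and 1 oxygen is therefore not silent to this change, although the reading rests on one pair. No measured evidence bears on what lies behind the step.

Going by these compounds, the change removes the chlorine and adds two fluorines at once, so their separate shares remain open. Whether 2-fluorophenyl or unsubstituted phenyl at this carbon would stay nearer compound 1 or compound 3 is also unresolved.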